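The source may hold more compounds than are shown below. What is called first, only, known or untested is meant among the compounds shown, and "the series" means these compounds.

Compound 1 `CC(C)=Cc1c(-c2ccccc2)sc(C(C)C)c1/C=C/[C@@H](O)C[C@@H](O)CC(=O)O` gives 1000 nM in an assay on microsomes for inhibition of 3-hydroxy-3-methylglutaryl-coenzyme A reductase (Rattus norvegicus); on this read-out higher numbers stand for weaker inhibition and lower numbers for stronger inhibition.
Compound 2 `CC(C)c1sc(-c2ccccc2)c(C2CCCCC2)c1/C=C/[C@@H](O)C[C@@H](O)CC(=O)O` gives 202 nM in this assay.
Compound 3 `CC(C)c1sc(C(C)C)c(-c2ccc(F)cc2)c1/C=C/[C@@H](O)C[C@@H](O)CC(=O)O` gives 26 nM in this assay.

Compound 3 stands lowest of the three numbers; compound 2 is the nearest and compound 1 the furthest, both gaps lying beyond the scatter. Compound 4 `Cc1ccc(-c2sc(C(C)C)c(/C=C/[C@@H](O)C[C@@H](O)CC(=O)O)c2-c2ccc(F)cc2)cc1` has not yet been measured. It differs from compound 3 in one place: 4-methylphenyl in place of isopropyl on an aromatic carbon. For the measured compounds named here, only one single-place step has been measured, a 5.0-fold lower number from compound 1 to compound 2 (0.69 log units; beyond the scatter), and it swaps one non-aromatic group for another rather than bringing an aromatic ring in for an isopropyl, so it bears only loosely on the present change. Compounds 1 and 3 differ in several places at once, so their values cannot be traced to any one change. Going by the values given here, with no close precedent, a change of moderate size in this assay is expected, in either direction, with a slight lean towards a higher number. Compound 4 is estimated at 60 nM, between 15 nM and 250 nM, which corresponds to a 2.3-fold higher number from compound 3 to compound 4 (0.36 log units; beyond the scatter).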

Compound 4, half-maximal inhibitory concentration: 9.7 nM
Beside the measured number, compound 4's estimate is 6.2-fold (0.79 log units) above it; measured number below the stated range.
By their numbers in this assay, from the lowest: compound 4; then compound 3; then compound 2; then compound 1.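

In this assay, putting 4-methylphenyl in place of isopropyl on the aromatic carbon next to the ring sulfur gives a 2.7-fold lower number from compound 3 to compound 4 (0.43 log units; beyond the scatter). For the compounds shown here, this is the first single-place step at this position, and it shows that a group with a six-membered aromatic ring and more heavy atoms than isopropyl can sit here without the number rising. No supporting measurement bears on why the number falls.

The compounds shown do not separate the contribution of the aromatic ring from that of its methyl group, so the same core with a methoxy group or an amine in place of that methyl remains an open comparison. On these data alone, it is also open whether a non-aromatic ring such as cyclohexyl at this position would give a similar number.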